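Swapping the side chain of compound 2 for phenyl

A few compounds are considered here, and "the series" means these few. Any claim that something is new, unique, unknown or untested is made for them only; others in the source may bear on it.

In a functional assay on a cell-free system (plasma, Homo sapiens), with a stated time of 3 min (on this read-out lower numbers stand for stronger inhibition and higher numbers for weaker inhibition), compound 1 (`O=C(NCc1cc(Cl)ccc1-n1cnnn1)[C@@H]1CC=NN1C(=O)[C@H](O)Cc1ccccc1`) gives 1400 nM and compound 2 (`COC(C)(C)[C@@H](O)C(=O)N1C[C@H]2C[C@H]2[C@H]1C(=O)NCc1cc(Cl)ccc1-n1cnnn1`) gives 1000 nM there. Within the data shown here, these two values lie within the usual scatter of each other, so compound 2 stands level with compound 1 on the numbers so far. Compound 3 (`O=C(NCc1cc(Cl)ccc1-n1cnnn1)[C@@H]1[C@@H]2C[C@@H]2CN1C(=O)[C@H](O)c1ccccc1`) has not yet been measured. The change from compound 2 (phenyl in place of 1-methoxy-1-methylethyl on a saturated chain carbon bound to a carbonyl carbon and an oxygen on a saturated carbon) puts phenyl in place of 1-methoxy-1-methylethyl on a saturated chain carbon bound to a carbonyl carbon and an oxygen on a saturated carbon. Among the measured compounds shown here, no measured pair shows this exchange alone, so any forecast is uncertain. A modest move towards a lower number in this assay is expected, though a result within the scatter would be no surprise. The estimated step (a 2.0-fold lower number from compound 2 to compound 3 (0.30 log units; within the scatter)) is correspondingly small. Compound 3 is expected to give about 500 nM with an estimated range from 120 nM to 2000 nM as the likely span.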

Compound 3, half-maximal inhibitory concentration: 700 nM
The estimate for compound 3 lay 1.4-fold (0.15 log units) below the measured number; measured number inside the range.
By their numbers in this assay, from the lowest: compounds 3, 2 and 1 (each within the scatter of the next).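

In this assay, among these compounds, phenyl in place of 1-methoxy-1-methylethyl on a saturated chain carbon bound to a carbonyl carbon and an oxygen on a saturated carbon gives a 1.4-fold lower number from compound 2 to compound 3 (0.15 log units; within the scatter) and is the first exchange at this position that can be read on its own. At this place, then, a group with no ring and 1 hydrogen-bond acceptor and a group with one six-membered aromatic ring of carbon only and no acceptor give numbers within the scatter of each other. No other measurement bears on this result, and nothing shown accounts for it.

From the compounds shown here alone, what an amine, a carboxylic acid or a longer chain would give at this place remains open. So does whether the same exchange would read alike on the core of compound 1.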